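Cytotoxicity of three benzamide variants and an expected fourth

The source may hold more compounds than are shown below. What is called first, only, known or untested is meant among the compounds shown, and "the series" means these compounds.

compound 1 `Cc1ccc(S(=O)(=O)N[C@@H](CC(=O)NC(C)(C)C)C(=O)NCCNC(=O)c2ccccc2)cc1` gives > 11100 nM
compound 2 `Cc1ccc(S(=O)(=O)N[C@@H](CC(=O)NC(C)(C)C)C(=O)NCCNC(=O)c2cccc(C(C)C)c2)cc1` gives > 11100 nM
compound 3 `Cc1ccc(S(=O)(=O)N[C@@H](CC(=O)NC(C)(C)C)C(=O)NCCNC(=O)c2cc(Cl)ccc2Cl)cc1` gives > 11100 nM

The three measured compounds share one core and differ only in the group on the carbonyl carbon. In an ADME assay on Karpas-1106P cells (Homo sapiens) for cytotoxicity (on this read-out higher numbers stand for an effect only at larger amounts of compound and lower numbers for an effect already at smaller amounts), compound 1 returns only a limit, > 11100 nM. Compound 2 likewise returns only a limit, > 11100 nM. Compound 3 also returns only a limit, > 11100 nM. Because every value sits at the limit of > 11100 nM in this assay, at which 3 of the 3 values shown sit, none of the steps among them can be read: a step that the two limits leave unreadable from compound 1 to compound 2, a step that the two limits leave unreadable from compound 1 to compound 3 and a step that the two limits leave unreadable from compound 2 to compound 3. Compound 3 therefore stands at the limit of this assay together with the other two, and no ordering among them can be drawn.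

Compound 4 `Cc1ccc(S(=O)(=O)N[C@@H](CC(=O)NC(C)(C)C)C(=O)NCCNC(=O)c2cccc(C(F)(F)F)c2)cc1` differs from compound 3 by 3-(trifluoromethyl)phenyl in place of 2,5-dichlorophenyl on a carbonyl carbon. For the measured compounds named here, the steps that bear on this change are unreadable, since they all run between limits. No step beyond the usual scatter is expected, so the step that the limit leaves unreadable from compound 3 to compound 4 is estimated to be flat. Compound 4 is therefore expected to give about 20000 nM, estimated between 11100 nM and 60000 nM, most probably again reported only as a limit.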

Compound 4, half-maximal effective concentration: > 11100 nM
Compound 4 ended at the assay's limit (the forecaster's own chance of this, stated with the estimate: 85%); the middle value does not contradict the limit.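

Compound 4 returns only a limit, as do compound 1, compound 2 and compound 3, so none of the new steps to compound 4 can be read: the limit of > 11100 nM in this assay, at which 4 of the 4 values shown sit.

The compounds shown leave open whether in this assay any group on the carbonyl carbon would give a value that is not a limit.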